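Working notes: methyl to fluoro, compound 3 to compound 4

The source may hold more compounds than are shown below. What is called first, only, known or untested is meant among the compounds shown, and "the series" means these compounds.

In a functional assay on HT-29 cells (Homo sapiens) for inhibition, read by CCK-8 assay, with a stated time of 24 h (on this read-out higher numbers stand for weaker inhibition and lower numbers for stronger inhibition), compound 3 `Cc1cccc(-n2cc(-c3ccc(/C=C4\C(=O)Nc5ccc(F)cc54)cc3)nn2)c1` gives 7320 nM. Compound 1 `Cc1cccc(-n2cc(-c3ccc(/C=C4\C(=O)Nc5ccccc54)cc3)nn2)c1` gives 3940 nM, and compound 2 `O=C1Nc2ccccc2/C1=C/c1ccc(-c2cn(-c3ccc(Cl)c(C(F)(F)F)c3)nn2)cc1` gives 9670 nM. Compound 3 lies within the scatter of both, so it holds no separate place on these numbers, although compound 1 and compound 2 differ from each other beyond the scatter.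

Compound 4 `O=C1Nc2ccc(F)cc2/C1=C/c1ccc(-c2cn(-c3cccc(F)c3)nn2)cc1` differs from compound 3 by fluoro in place of methyl on an aromatic carbon, that is 3-methylphenyl to 3-fluorophenyl: fluoro in place of methyl on an aromatic carbon.

Among the compounds with values here, two measured steps bear on this change. The closer one is a 2.5-fold higher number from compound 1 to compound 2 (0.39 log units; beyond the scatter), a modest step with 4-chloro-3-(trifluoromethyl)phenyl in place of 3-methylphenyl on an aromatic nitrogen. Within the data shown here, it replaces the same 3-methylphenyl group, but with a different group from the one in compound 4. The other is a 1.9-fold higher number from compound 1 to compound 3 (0.27 log units; within the scatter), with fluoro in place of hydrogen on an aromatic carbon, and it stays within the scatter. Compound 4 keeps that fluoro. Neither step gives grounds for a direction, so no step beyond the scatter is expected. The expected step is a 1.0-fold lower number from compound 3 to compound 4 (0.02 log units; within the scatter). In this assay the estimate for compound 4 is 7000 nM, expected to fall between 3500 nM and 14000 nM.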

Compound 4, half-maximal inhibitory concentration: > 12900 nM
Compound 4: a limit, no number; the forecaster's own chance of this, stated with the estimate: 5%; at least 1.8-fold (0.26 log units) between middle value and limit.
By their numbers in this assay, from the lowest: compounds 1, 3 and 2 (each within the scatter of the next, the first and the last beyond it). At a limit, above all of these: compound 4.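

In this assay compound 4 gives > 12900 nM, which is a limit and not a number. As far as these compounds go, the change from methyl to fluoro swaps a single heavy atom on the 3-methylphenyl group and gives an at least 1.7-fold higher number from compound 3 to compound 4 (0.24 log units; that floor lies within the scatter), so the floor alone does not place this change beyond the scatter, and the true size of the step remains unknown. Set beside a 2.5-fold higher number from compound 1 to compound 2 (0.39 log units; beyond the scatter), it gives two replacements of 3-methylphenyl that both move towards a higher number, the newer one with the fluoro kept on the core, and neither pair goes against this, though two pairs are a narrow base and only one value among the compounds shown sits at the limit: the limit of > 12900 nM in this assay, at which 1 of the 4 values shown sits.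

From the compounds shown here alone, how far compound 4 lies past its limit stays open, so the two replacement steps cannot be ranked against each other. Also open, going by these compounds, are the 3-fluorophenyl group on the core of compound 1, without the core fluoro, and what an amine or a carboxylic acid would do in place of the methyl.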